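This account rests on a few compounds, and the source may have more. Where it says the series, first, only, none or still open, it means among the compounds named here.

Compound 2 `O=C(O)CCc1ccc(-c2ccc3cnn(-c4ccccn4)c3c2)cc1` gives 4500 nM in a functional assay on cells for agonist activity at Free fatty acid receptor 1 (Mus musculus), read by FLIPR and calcium flux, with a stated time of 5 min (on this read-out lower numbers stand for an effect already at smaller amounts and higher numbers for an effect only at larger amounts of compound), the lower of the two numbers in hand. Compound 1 `Cc1nn(-c2ccccn2)c2cc(-c3ccc(CCC(=O)O)cc3)ncc12`, with a methyl group on a different core, gives 9200 nM in this assay, a gap beyond the usual scatter. Compound 3 `CCc1nn(-c2ccccn2)c2cc(-c3ccc(CCC(=O)O)cc3)ccc12` keeps the core of compound 2 and carries ethyl in place of hydrogen on an aromatic carbon. For the measured compounds named here, no measured pair isolates this change, so any direction is uncertain; a modest move, likely within or only just beyond the scatter, is expected, as a 1.5-fold lower number from compound 2 to compound 3 (0.18 log units; within the scatter). Compound 3 is therefore estimated at 3000 nM, ranging from 1200 nM to 8000 nM.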

Compound 3, half-maximal effective concentration: 1100 nM
The estimate for compound 3 lay 2.7-fold (0.44 log units) above the measured number; measured number outside the range, below it.
By their numbers in this assay, from the lowest: compound 3; then compound 2; then compound 1.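

In this assay, ethyl in place of hydrogen on an aromatic carbon of the five-membered ring gives a 4.1-fold lower number from compound 2 to compound 3 (0.61 log units; beyond the scatter). This shows that the position, two ring bonds from the ring atom that bears the pyridin-2-yl group, responds to substitution, which compound 1, with its methyl group on a different core, could not show. Nothing at hand accounts for this step. As far as these compounds go, whether methyl, a longer chain such as propyl, or an amine at this position would act like ethyl on the core of compound 2 stays open. Also open, from the compounds shown here alone, is whether ethyl would give a similar step on the core of compound 1.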